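This account rests on a few compounds, and the source may have more. Where it says the series, first, only, none or still open, it means among the compounds named here.

In a physicochemical assay for lipophilicity (a lower number here means a more polar compound, a higher number a more lipophilic compound), compound 1 `CC(C)CN(C1=NCCN1)c1c(Br)cccc1Br` gives -0.64 and compound 2 `CC(C)=CCN(C1=NCCN1)c1c(Br)cccc1Br` gives -0.14, the higher of the two numbers. Compound 3 `C=C(C)CCN(C1=NCCN1)c1c(Br)cccc1Br` has the same atoms as compound 2, joined differently: 2-methylprop-2-en-1-yl in place of 2-methylprop-1-en-1-yl on a saturated chain carbon bound to a nitrogen on an aromatic ring. It carries 2-methylprop-2-en-1-yl in place of 2-methylprop-1-en-1-yl on a saturated chain carbon bound to a nitrogen on an aromatic ring. Within the data shown here, only one measured step bears on this, and only indirectly. The step of a number 0.50 log units higher from compound 1 to compound 2 (beyond the scatter) is modest and beyond the scatter, but it replaced isopropyl with 2-methylprop-1-en-1-yl, a different exchange from the one made here. Among the measured compounds shown here, no measured pair yet shows an exchange between two groups with matching counts, so the expectation remains tentative. The expected step, a number 0.06 log units lower from compound 2 to compound 3 (within the scatter), is estimated to stay within the scatter, with no clear direction. For compound 3 the estimated value is -0.2, within an expected range of -0.5 to 0.1.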

Compound 3, distribution coefficient: 0.02
Beside the measured number, compound 3's estimate is 0.22 log units below it, within the range that was stated.
By their numbers in this assay, from the lowest: compound 1; then compounds 2 and 3 (each within the scatter of the next).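

In this assay the exchange of 2-methylprop-1-en-1-yl for 2-methylprop-2-en-1-yl, on a saturated chain carbon bound to a nitrogen on an aromatic ring, gives a number 0.16 log units higher from compound 2 to compound 3 (within the scatter) and so shows that, at this position, these two arrangements of the same atoms cannot be told apart in this measurement. Set against isopropyl, the new group gives a number 0.66 log units higher from compound 1 to compound 3 (beyond the scatter) and so shows that the separation from compound 1 seen with one unsaturated group also holds for a second. Nothing available explains either step.

Going by these compounds, whether a longer chain or a chain ending in a hydroxyl group would fall with compound 1 or with compound 2 and compound 3 stays open. So does whether the same exchange would behave alike on a different core.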